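A few compounds are considered here, and "the series" means these few. Any claim that something is new, unique, unknown or untested is made for them only; others in the source may bear on it.

Compound 1 `Cc1cc(NC(=O)c2cccc(C(F)(F)F)c2)ccc1NS(C)(=O)=O` in an ADME assay on HEK293 cells (Homo sapiens) for cytotoxicity, read by MTT assay, with a stated time of 48 h (a higher number here means a weaker inhibitor, a lower number a stronger inhibitor), gives 194000 nM. Compound 2 `COc1cc(NC(=O)c2cccc(C(F)(F)F)c2)ccc1NS(C)(=O)=O` in this assay gives only a limit of the assay, > 250000 nM. Compound 3 `CS(=O)(=O)Nc1ccc(NC(=O)c2cccc(C(F)(F)F)c2)cc1Cl` in this assay likewise gives only a limit, > 250000 nM.

Compound 3 therefore stands at the limit of > 250000 nM in this assay, at which 2 of the 3 values shown sit, so only a floor is known for it. Compound 4 `CS(=O)(=O)Nc1ccc(NC(=O)c2cccc(C(F)(F)F)c2)cc1F` differs from it by fluoro in place of chloro on an aromatic carbon. The measured steps that swap one small group, an at least 1.2-fold higher number from compound 1 to compound 2 (0.11 log units; that floor lies within the scatter) and an at least 1.2-fold higher number from compound 1 to compound 3 (0.11 log units; that floor lies within the scatter), reach only a floor that lies within the scatter, and a step that the two limits leave unreadable from compound 2 to compound 3 cannot be read at all. No step beyond the scatter is thus expected in this assay, and a limit may again be all that comes back. Compound 4 is expected to give about 250000 nM, between 150000 nM and 400000 nM, an expected step of a number no higher from compound 3 to compound 4 (the limit leaves the size open).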

Compound 4, half-maximal inhibitory concentration: > 250000 nM
Compound 4 ended at the assay's limit; the forecaster's own chance of this, stated with the estimate: 60%; the middle value sits exactly at the limit.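

Compound 4 makes fluoro the third group, after methoxy and chloro, that reaches the limit when placed ortho to a methanesulfonamido group in this assay: the limit of > 250000 nM in this assay, at which 3 of the 4 values shown sit.

Against the methyl of compound 1, the swap gives an at least 1.2-fold higher number from compound 1 to compound 4 (0.11 log units; that floor lies within the scatter). The steps among compound 2, compound 3 and compound 4 cannot be read, as all three values are limits.

Going by these compounds, whether these three groups differ from one another, or truly from methyl, remains open. So does what an amine or a carboxylic acid at this position would give in this assay.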